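Compound 3 to compound 4: working notes

The compounds below may be only part of what the source reports. "The series", "measured", "known", "first", "only" and "open" are said of these compounds alone.

Measured in an ADME assay on L1210/0 cells (Mus musculus) for cytotoxicity, with a stated time of 48 h; on this read-out higher numbers stand for weaker inhibition and lower numbers for stronger inhibition:
- compound 1 `Nc1nc(Cl)c2nnn(C[C@H]3CC[C@@H](CO)C3)c2n1`: 170000 nM
- compound 2 `O=C1O/C(=C/Cn2cnc3c(-n4cccc4)ncnc32)C(OCc2ccccc2)=C1OCc1ccccc1`: 110000 nM
- compound 3 `N#CSc1cn([C@H]2C[C@H](O)[C@@H](CO)O2)c(=O)[nH]c1=O`: 78900 nM

Compound 3 shares the low end of this small set with compound 2, the two lying within the scatter of each other. Compound 1 has a higher number than compound 3, beyond the scatter.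

Compound 4 `O=c1[nH]c(=O)n([C@H]2C[C@H](O)[C@@H](CO)O2)cc1C#CCCO` is still unmeasured. It keeps the core of compound 3 and differs by 4-hydroxybut-1-yn-1-yl in place of cyanosulfanyl on an aromatic carbon, with 4-hydroxybut-1-yn-1-yl in place of cyanosulfanyl on an aromatic carbon.

Within the data shown here, no measured pair differs in one place, so the data offer no direct precedent for this change. The expectation therefore rests on compound 3 at 78900 nM, and no step beyond the scatter is expected in this assay. The estimated step is a 1.3-fold higher number from compound 3 to compound 4 (0.10 log units; within the scatter), with a slight expected lean toward weaker inhibition. For compound 4 the estimate is 100000 nM, with an expected range of 35000 nM to 280000 nM.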

Compound 4, half-maximal inhibitory concentration: > 200000 nM
Compound 4: a limit, no number; the forecaster's own chance of this, stated with the estimate: 35%; middle value at least 2.0-fold (0.30 log units) away from the limit.
By their numbers in this assay, from the lowest: compounds 3, 2 and 1 (each within the scatter of the next, the first and the last beyond it). At a limit, above all of these: compound 4.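

In this assay, the aromatic carbon two atoms from the ring nitrogen now has its first one-place comparison, as 4-hydroxybut-1-yn-1-yl in place of cyanosulfanyl on the shared core gives an at least 2.5-fold higher number from compound 3 to compound 4 (0.40 log units; beyond the scatter). Compound 4 reads > 200000 nM, which is a limit and not a number. The group at this position therefore matters in this read-out, but the full size of the step cannot be stated: the limit of > 200000 nM in this assay, at which 1 of the 4 values shown sits.

This single pair does not separate the contribution of the hydroxyl from that of the triple bond or from the departure of cyanosulfanyl, since all of these change together. Also open, from the compounds shown here alone, is how an amine, a carboxylic acid or a longer chain in place of 4-hydroxybut-1-yn-1-yl would read in this assay.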